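Methoxystyryl lactam series: growth inhibition working notes

The source may hold more compounds than are shown below. What is called first, only, known or untested is meant among the compounds shown, and "the series" means these compounds.

Measured so far:
compound 1, `COc1ccc(/C=C/C2CC=CC(=O)N2)cc1`: > 1090 uM
compound 2, `COc1ccc(/C=C/C2CC=CC(=O)N2)c(OC)c1`: > 964 uM
compound 3, `COc1cc(/C=C/C2CC=CC(=O)N2)cc(OC)c1`: 197 uM

In a functional assay on HT-29 cells (Homo sapiens) for inhibition, read by sulforhodamine B assay, with a stated time of 48 h (on this read-out higher numbers stand for weaker inhibition of growth and lower numbers for stronger inhibition of growth), compound 1 gives only a limit of the assay, > 1090 uM. Compound 2 likewise gives only a limit in this assay, > 964 uM. For the measured compounds named here, compound 3 is the one member of the set with a real number in this assay, 197 uM. The difference between the core of compound 1 and the core of compound 3 is not broken down here.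

The change from compound 1 to compound 2 is methoxy in place of hydrogen on an aromatic carbon. Its step, a step that the two limits leave unreadable from compound 1 to compound 2, cannot be sized because the limit of > 1090 uM in this assay, at which 1 of the 3 values shown sits, and the limit of > 964 uM in this assay, at which 1 of the 3 values shown sits, are the two values that bound it.

Compound 4, `COc1cc(/C=C/C2CC=CC(=O)N2)cc(OC)c1OC`, is not yet measured in this assay. It arises from compound 3 by methoxy in place of hydrogen on an aromatic carbon. This is the same kind of change as that from compound 1 to compound 2, not the same: in compound 2 the entering methoxy sits ortho to a group of 9 heavy atoms and meta to a methoxy group, whereas in compound 4 it sits ortho to two methoxy groups and para to a group of 9 heavy atoms.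

The earlier step offers no readable size, so the expectation for compound 4 rests on compound 3 and its 197 uM alone. The step from compound 3 to compound 4 is expected to be a 3.3-fold lower number from compound 3 to compound 4 (0.52 log units; beyond the scatter). Compound 4 is estimated at 60 uM in this assay, with an expected span from 10 uM to 250 uM.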

Compound 4, concentration for growth inhibition (reported as GI): > 864 uM
Compound 4: no number, only a limit; the forecaster's own chance of this, stated with the estimate: 10%; middle value at least 14-fold (1.15 log units) from the limit.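

In this assay, methoxy in place of hydrogen on an aromatic carbon gives an at least 4.3-fold higher number from compound 3 to compound 4 (0.64 log units; beyond the scatter), so on this core the change goes with weaker inhibition of growth. On these data alone, compound 4 gives only a limit, so the true size of that step stays unknown and only its direction and minimum size can be read: the limit of > 864 uM in this assay, at which 1 of the 4 values shown sits. The step from compound 1 to compound 2 cannot be read, so the data do not show whether the change has the same effect on both cores, and the change of core is not separated from the change of place, the methoxy of compound 4 being ortho to two methoxy groups and para to a group of 9 heavy atoms.

The compounds shown leave open whether another group at this place in this assay, such as a hydroxyl, an amine or a carboxylic acid, would stay near compound 3 at 197 uM. They also leave open whether an ethoxy or a longer chain in place of the methoxy groups of compound 3 would move the number in either direction.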